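Lengthening the chain from compound 3 to compound 4

The source may hold more compounds than are shown below. What is called first, only, known or untested is meant among the compounds shown, and "the series" means these compounds.

In a functional assay, with a stated time of 10 min (a lower number here means a stronger inhibitor, a higher number a weaker inhibitor), compound 3 (`CCCCCCCCOc1cc(OC)ccc1C(C)=O`) gives 69400000 nM as its value, which lies within the scatter of both other measured compounds. Compound 2 (`CCCCOc1cc(OC)ccc1C(C)=O`) gives 57200000 nM in the same test, and compound 1 (`CCCCCCCCOc1cc(OC)c(Br)cc1C(C)=O`) gives 38100000 nM there.

Compound 4 (`CCCCCCCCCCCCOc1cc(OC)ccc1C(C)=O`) differs from compound 3 by a single change (butyl in place of hydrogen on a saturated chain carbon, eight bonds along the chain from an oxygen on an aromatic ring), butyl in place of hydrogen on a saturated chain carbon, eight bonds along the chain from an oxygen on an aromatic ring. For the measured compounds named here, the closest precedent is the same replacement made four bonds along the chain (a 1.2-fold higher number from compound 2 to compound 3 (0.08 log units; within the scatter)), a step within the scatter. The bromo to hydrogen step (a 1.8-fold higher number from compound 1 to compound 3 (0.26 log units; within the scatter)) is also within the scatter, but it lies elsewhere on the structure and bears on this change only weakly. Going by the values given here, no measured compound has a chain longer than octyl, so this remains an extrapolation.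

No step beyond the scatter is therefore expected in this assay for this change. The estimated step is small (a 1.1-fold lower number from compound 3 to compound 4 (0.05 log units; within the scatter)) and within the scatter. The estimate for compound 4 is 62000000 nM with 28000000 nM and 130000000 nM as the expected ends of its range.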

Compound 4, half-maximal inhibitory concentration: 65600000 nM
Compound 4: middle estimate off by 1.1-fold (0.02 log units), on the low side, and the stated range covers the measured number.
By their numbers in this assay, from the lowest: compounds 1, 2, 4 and 3 (each within the scatter of the next).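

In this assay the butyl in place of hydrogen eight bonds along the chain from the oxygen on the aromatic ring gives a step within the scatter (a 1.1-fold lower number from compound 3 to compound 4 (0.02 log units; within the scatter)), so the flat response seen four bonds along the chain also holds at this further position. The octyl in place of hydrogen four bonds along the chain is also within the scatter (a 1.1-fold higher number from compound 2 to compound 4 (0.06 log units; within the scatter)), so the two butyl extensions taken together do not build into a step beyond it, and none of compounds 2, 3 and 4 goes against this. No separate measurement is available to explain this result.

As far as these compounds go, whether a chain longer than that of compound 4 would leave the number in place remains open. So does the effect of an amine or a carboxylic acid at the end of the chain.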